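A few compounds are considered here, and "the series" means these few. Any claim that something is new, unique, unknown or untested is made for them only; others in the source may bear on it.

Working notes on the series. In a functional assay on HO8910 cells (Homo sapiens) for inhibition, read by MTT assay, with a stated time of 24 h, tested at 100 ug/mL (on this read-out higher numbers stand for more inhibition of growth at the one concentration tested and lower numbers for less inhibition of growth), compound 1 (`O=C(O)CCCCC(CCSC(=O)c1ccccc1)SC(=O)c1ccccc1`) gives 86.7%, the highest of the three measured values and beyond the scatter of the other two. Compound 3 (`O=C(CCCCC(S)CCS)Nc1ccc(Br)cn1`) gives 56.8%, and compound 2 (`COc1ccc(NC(=O)CCCCC(S)CCS)cc1`) gives 12.6%.

Compound 4 (`O=C(CCCCC(CCSC(=O)c1ccccc1)SC(=O)c1ccccc1)Nc1cccc(Cl)c1`) keeps the rest of compound 1 but has (3-chlorophenyl)amino in place of hydroxy on a carbonyl carbon. Among the measured compounds shown here, no measured pair isolates this change. Compound 2 and compound 3 also lack the hydroxy on that carbonyl carbon and both read lower than compound 1, but they differ from it at the sulfur atoms as well, so they give only weak guidance. Compound 4 retains both benzoyl-bearing sulfur atoms of compound 1, which argues against a fall as deep as that seen with compound 2 at 12.6%.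

A moderate downward step beyond the scatter is expected, estimated as a number 18.7 percentage points lower from compound 1 to compound 4 (beyond the scatter). The estimated value for compound 4 is 68%, with an expected range of 42% to 88%.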

Compound 4, percent growth inhibition at one concentration: "not active" (no number reported)
No number was reported for compound 4; no gap can be computed for the estimate.
By their numbers in this assay, from the lowest: compound 2; then compound 3; then compound 1.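

Among the compounds shown here, compound 4 is reported as "not active" in this assay with no number, so no step from compound 1 to compound 4 can be read. No available evidence bears on this result. The compounds shown leave open how much activity depends on hydroxy on the carbonyl carbon when both sulfur atoms carry benzoyl groups.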